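A few compounds are considered here, and "the series" means these few. Any claim that something is new, unique, unknown or untested is made for them only; others in the source may bear on it.

Measured so far in a physicochemical assay for lipophilicity, read by HPLC, measured as chromatographic lipophilicity, at pH 7.4; on this read-out higher numbers stand for higher lipophilicity and lower numbers for lower lipophilicity
compound 1 `N#Cc1ccc(N2CCC(C(=O)N3N=CC[C@H]3c3cc(F)cc(F)c3)CC2)nn1` gives 4.8
compound 2 `C[C@@H]1C=NN(C(=O)C(C)(C)C)[C@@H]1c1ccccc1` gives 6.5
compound 3 `O=C(c1cccnc1)N1N=CCC1c1ccccc1` gives 2.7

Compound 3 stands lowest of the three, and its gaps to compound 1 and to compound 2 both lie beyond the scatter. Next in line is compound 4 `O=C(C1CCOCC1)N1N=CCC1c1ccccc1`, not yet measured. The change from compound 3 is oxan-4-yl in place of pyridin-3-yl on a carbonyl carbon. Within the data shown here, no measured pair differs in one place only, so the expectation rests on the structural change alone and remains loose. The expected step is a small rise (a number 0.30 log units higher from compound 3 to compound 4 (within the scatter)), not clearly beyond the scatter. Expected for compound 4 in this assay is 3 (estimated range 2.5 to 3.6).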

Compound 4, distribution coefficient: 3.1
Compound 4: the middle estimate sits 0.10 log units below what was measured; low and high end bracket the measured number.
By their numbers in this assay, from the lowest: compound 3; then compound 4; then compound 1; then compound 2.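

In this assay, among these compounds, the first comparison that differs in one place gives a number 0.40 log units higher from compound 3 to compound 4 (beyond the scatter) with oxan-4-yl in place of pyridin-3-yl on a carbonyl carbon. This shows that on this carbonyl carbon, swapping an aromatic six-membered ring for a non-aromatic one moves the number modestly but beyond the scatter. Nothing available accounts for the step.

From the compounds shown here alone, what an amine or a longer alkyl chain on this carbonyl carbon would give remains open. So does whether the step carries over to the cores of compound 1 and compound 2.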